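Swapping a Cyclobutyl for a Bicyclic Amine on Two Cores

The source may report more compounds than this note shows. Statements on the series, on what has been measured and on what is new or still open speak of the compounds shown alone.

Measured so far:
Compound 1, `[O-][n+]1nc(NC2CCC2)[n+]([O-])c2ccc(Cl)cc21`: 1.6 ug/mL
Compound 2, `[O-][n+]1nc(N[C@@H]2C[C@H]3CC[C@@H]2C3)[n+]([O-])c2ccc(Cl)cc21`: 1.1 ug/mL
Compound 3, `COc1cc2c(cc1C)[n+]([O-])nc(NC1CCC1)[n+]2[O-]`: > 50 ug/mL

In an ADME assay on Vero cells (Chlorocebus sabaeus) for cytotoxicity, read by CellTiter-Glo, with a stated time of 72 h (a lower number here means that less compound is tolerated, a higher number that more compound is tolerated), compound 1 gives 1.6 ug/mL and compound 2 gives 1.1 ug/mL. The two structures differ by a group of 7 heavy atoms (7 carbon; 2 five-membered non-aromatic rings of carbon only) in place of a group of 4 heavy atoms (4 carbon; one four-membered non-aromatic ring of carbon only), on a nitrogen on an aromatic ring, and the step between them is a 1.5-fold lower number from compound 1 to compound 2 (0.16 log units; within the scatter). Compound 3 is built on another core; the difference between the core of compound 1 and the core of compound 3 is not broken down here. For compound 3 the reading in this assay is a limit of the assay and not a number, > 50 ug/mL, which is the limit of > 50 ug/mL in this assay, at which 1 of the 3 values shown sits. Compound 4, `COc1cc2c(cc1C)[n+]([O-])nc(N[C@@H]1C[C@H]3CC[C@@H]1C3)[n+]2[O-]`, has not yet been measured in this assay. It differs from compound 3 by a group of 7 heavy atoms (7 carbon; 2 five-membered non-aromatic rings of carbon only) in place of a group of 4 heavy atoms (4 carbon; one four-membered non-aromatic ring of carbon only), on a nitrogen on an aromatic ring, the same change as between compound 1 and compound 2, at the same place. Since that change gave only a 1.5-fold lower number from compound 1 to compound 2 (0.16 log units; within the scatter) on the core of compound 1, the step from compound 3 to compound 4 is expected to be small, about a number no higher from compound 3 to compound 4 (the limit leaves the size open). Compound 4 is therefore estimated at 50 ug/mL, between 20 ug/mL and 100 ug/mL, and it is expected that this assay may again return only a limit.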

Compound 4, half-maximal cytotoxic concentration: > 50 ug/mL
Compound 4 gave a limit, no number (the forecaster's own chance of this, stated with the estimate: 70%); the middle value lies on the limit itself.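

In this assay compound 3 and compound 4 both return a limit and not a number, so no step between them can be read: the limit of > 50 ug/mL in this assay, at which 2 of the 4 values shown sit.

Going by these compounds, whether replacing cyclobutyl changes the reading on the core of compound 3 as little as it does on the core of compound 1 stays open, as does the actual tolerated concentration of either compound.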